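Swapping the nitrophenyl arm for a fluorophenyl

A few compounds are considered here, and "the series" means these few. Any claim that something is new, unique, unknown or untested is made for them only; others in the source may bear on it.

Compound 1 `Cc1cnc(Nc2ccc([N+](=O)[O-])cc2)nc1Nc1nc2ccccc2s1`: > 50000 nM
Compound 2 `NS(=O)(=O)c1ccc(Nc2nccc(Nc3nc4ccccc4s3)n2)cc1`: 15300 nM
Compound 3 `Cc1cnc(Nc2ccc(S(C)(=O)=O)cc2)nc1Nc1nc2ccc(F)cc2s1`: 3260 nM

In a functional assay on MCF7 cells (Homo sapiens) for antiproliferative activity, read by MTT assay, with a stated time of 48 h (a higher number here means a weaker inhibitor, a lower number a stronger inhibitor), compound 1 gives only a limit, > 50000 nM, not a measured number. Compound 1 therefore stands at the limit of > 50000 nM in this assay, at which 1 of the 3 values shown sits. Among the measured numbers, compound 2 gives 15300 nM and compound 3 gives 3260 nM in this assay.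

Compound 4 `Cc1cnc(Nc2cccc(F)c2)nc1Nc1nc2ccccc2s1` keeps the shared core of compound 1 and differs in one place: 3-fluorophenyl in place of 4-nitrophenyl on a nitrogen on an aromatic ring. Going by the values given here, since compound 1 has no number, the step cannot be sized from measured pairs; with compound 3 at 3260 nM as the only guide to this series, a shift toward a stronger inhibitor, somewhat beyond the scatter, is expected. Compound 4 is expected to give 20000 nM, between 4000 nM and 80000 nM. This estimate implies a step of an at least 2.5-fold lower number from compound 1 to compound 4 (0.39 log units; beyond the scatter).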

Compound 4, half-maximal inhibitory concentration: > 50000 nM
Compound 4 was reported as a limit; the forecaster's own chance of this, stated with the estimate: 40%; middle value at least 2.5-fold (0.39 log units) from the limit.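

Compound 1 and compound 4 both give only a limit in this assay, not a measured number, so no step between them can be read: the limit of > 50000 nM in this assay, at which 2 of the 4 values shown sit.

The compounds shown leave open whether 3-fluorophenyl or 4-nitrophenyl gives the stronger inhibitor on the shared core.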